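This account rests on a few compounds, and the source may have more. Where it says the series, first, only, none or still open, it means among the compounds named here.

Measured so far:
compound 1 `COc1ccc(C(=O)/C=C/c2cc3ccccc3[nH]c2=O)cc1`: 8890 nM
compound 2 `O=C(/C=C/c1cc2ccccc2[nH]c1=O)c1ccc(O)cc1`: 4450 nM

In a functional assay on SW-620 cells (Homo sapiens) for cytotoxicity, read by sulforhodamine B assay, with a stated time of 24 h (a higher number here means a weaker inhibitor of growth, a lower number a stronger inhibitor of growth), compound 2 gives 4450 nM; compound 1 gives 8890 nM, and the two lie within the scatter of each other. Compound 3 `O=C(/C=C/c1cc2ccccc2[nH]c1=O)c1ccc(Cl)cc1` is not yet measured and differs from compound 2 by chloro in place of hydroxy on an aromatic carbon. No measured step covers a change of this kind; the only step shown, a 2.0-fold lower number from compound 1 to compound 2 (0.30 log units; within the scatter), concerns the hydroxy that now leaves and was itself small. Nothing therefore points to a shift in this assay beyond the scatter in either direction. Compound 3 is expected to give 5000 nM (range 2000 nM to 15000 nM). The expected step is a 1.1-fold higher number from compound 2 to compound 3 (0.05 log units; within the scatter).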

Compound 3, concentration for total growth inhibition: 12100 nM
Beside the measured number, compound 3's estimate is 2.4-fold (0.38 log units) below it, within the range that was stated.
By their numbers in this assay, from the lowest: compounds 2, 1 and 3 (each within the scatter of the next, the first and the last beyond it).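

In this assay, among these compounds, going from 4-hydroxyphenyl to 4-chlorophenyl gives the first step beyond the scatter (a 2.7-fold higher number from compound 2 to compound 3 (0.43 log units; beyond the scatter)), so the number at this position can respond to the group it carries. Chloro in place of methoxy stays small (a 1.4-fold higher number from compound 1 to compound 3 (0.13 log units; within the scatter)), which sets compound 2 apart from compound 3 only. No measurement available here bears on what lies behind the step.

As far as these compounds go, whether an amine or a carboxylic acid at this position would move the number further in either direction remains open. So does whether fluoro or bromo would follow chloro.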